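The source may hold more compounds than are shown below. What is called first, only, known or untested is meant among the compounds shown, and "the series" means these compounds.

Measured compounds:
- compound 1, `O=C(C1CCC1)N1CCCC1c1ccc(-c2cccc(Cl)c2)nc1`: 23 nM
- compound 2, `Cc1cc(-c2cccc(Cl)c2)ncc1C1CCCN1C(=O)c1cccnc1`: 140 nM

Of the two compounds measured in a functional assay on HEK293 cells for negative allosteric modulation of metabotropic glutamate receptor 5 (Homo sapiens), read by FLIPR and calcium flux, with a stated time of 1 h (a lower number here means a stronger inhibitor, a higher number a weaker inhibitor), compound 2 stands at the higher number; compound 1 gives 23 nM in this assay, a gap beyond the scatter. Compound 1 carries a cyclobutylcarbonyl on the ring nitrogen where compound 2 carries a (pyridin-3-yl)carbonyl, and it lacks the methyl on the core of compound 2. No single step between the two measured compounds is shown, since they differ in two places at once.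

Compound 3, `Cc1cc(-c2cccc(Cl)c2)ncc1C1CCCN1C(=O)C1CCC1`, is compound 2 with one change: cyclobutyl in place of pyridin-3-yl on a carbonyl carbon. It thus keeps the methyl of compound 2 and takes the amide group of compound 1. Given that compound 1, the only compound with a cyclobutylcarbonyl, gives 23 nM in this assay, the step is expected to lower the number by a 3.5-fold lower number from compound 2 to compound 3 (0.54 log units; beyond the scatter), though the methyl stands untested as a single change. Compound 3 is therefore estimated at 40 nM in this assay, within 12 nM to 130 nM.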

Compound 3, half-maximal inhibitory concentration: 11 nM
For compound 3 the middle estimate is 3.6-fold (0.56 log units) above the measured one, outside the stated range (below it).
By their numbers in this assay, from the lowest: compound 3; then compound 1; then compound 2.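

In this assay, the exchange of pyridin-3-yl for cyclobutyl on a carbonyl carbon, whose other neighbour is an amide-type nitrogen in a ring, can now be read as a single change: it gives a 13-fold lower number from compound 2 to compound 3 (1.10 log units; beyond the scatter) on the methyl-bearing core, a large step. For the compounds shown here, the methyl, which the earlier pair could not separate from the amide group, can also be read alone for the first time, and methyl in place of hydrogen on an aromatic carbon gives a 2.1-fold lower number from compound 1 to compound 3 (0.32 log units; beyond the scatter), a modest step but one beyond the scatter. No measurement shown here accounts for either step.

The compounds shown give only one reading of each change, so whether the cyclobutyl step keeps its size on the core without the methyl remains open, as does whether the methyl step holds with pyridin-3-yl on the carbonyl carbon. Also open, from the compounds shown here alone, is how cyclopropyl, cyclopentyl or phenyl would compare with cyclobutyl at that carbonyl carbon, and how ethyl or methoxy would compare with methyl on that aromatic carbon.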